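This account rests on a few compounds, and the source may have more. Where it says the series, first, only, none or still open, it means among the compounds named here.

Measured so far:
Compound 1, `C[C@H](NC(=O)c1cc(C(F)(F)F)nn1C)c1nc(-c2ccnc(N3CCCC3)c2)no1`, in a physicochemical assay for solubility, measured as kinetic solubility (a higher number here means a more soluble compound, a lower number a less soluble compound), gives 41000 nM.
Compound 2, `COc1cc(-c2noc([C@H](C)NC(=O)c3cc(C(F)(F)F)nn3C)n2)cc(C)n1`, in this assay gives 3000 nM.

Of these two numbers, compound 2 stands lowest, and the gap to compound 1 is beyond the scatter. Among the compounds with values here, no pair of measured compounds differing in a single place is available, so the two values only show that compound 2 sits well under compound 1 in this assay.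

Compound 3, `C[C@H](NC(=O)c1cc(C(F)(F)F)nn1C)c1nc(-c2ccnc(C(F)(F)F)c2)no1`, has not yet been measured in this assay. It differs from compound 2 in one place: 2-(trifluoromethyl)pyridin-4-yl in place of 2-methoxy-6-methylpyridin-4-yl on an aromatic carbon. Within the data shown here, nothing measured bears on this particular exchange; the two numbers known here do not include it. The account therefore expects the step of a 1.3-fold higher number from compound 2 to compound 3 (0.12 log units; within the scatter) to stay within the scatter, with no clear direction.

On that basis compound 3 is estimated at 4000 nM in this assay, in a range from 1500 nM to 12000 nM.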

Compound 3, solubility: 58000 nM
Compound 3: middle estimate off by 15-fold (1.16 log units), on the low side; the measured number lies above the stated range.
By their numbers in this assay, from the lowest: compound 2; then compounds 1 and 3 (each within the scatter of the next).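

At this position on the shared core, 2-(trifluoromethyl)pyridin-4-yl in place of 2-methoxy-6-methylpyridin-4-yl gives a 19-fold higher number from compound 2 to compound 3 (1.29 log units; beyond the scatter) in this assay, the first single-place step measured here, and it shows that the exchange is far from neutral. The second step, trifluoromethyl in place of pyrrolidin-1-yl on an aromatic carbon, gives a 1.4-fold higher number from compound 1 to compound 3 (0.15 log units; within the scatter), so these two groups cannot be told apart in this read-out, and only compound 2 stands apart among the three. Nothing available explains the large step.

On these data alone, the methoxy and the methyl of compound 2 leave together in this exchange, so it remains open whether a pyridine keeping only the methoxy or only the methyl would read like compound 2 or like compound 3. As far as these compounds go, how a morpholine or a nitrile would read at the same place in this assay is also open.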